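The source may hold more compounds than are shown below. What is called first, only, known or untested is meant among the compounds shown, and "the series" means these compounds.

Of the compounds shown here, two with a shared core have numbers so far in a functional assay on HT-29 cells (Homo sapiens) for antiproliferative activity, read by sulforhodamine B assay, with a stated time of 48 h (a lower number here means a stronger inhibitor, a higher number a weaker inhibitor), and they sit close together. Compound 1 (`O=C1NCCN1c1ccc(S(=O)(=O)Nc2ccc3[nH]ccc3c2)cc1`) gives 130 nM and compound 2 (`Cc1ccc(NS(=O)(=O)c2ccc(N3CCNC3=O)cc2)cc1C`) gives 230 nM there, so compound 2 stands within the usual scatter of compound 1. Compound 3 (`O=C1NCCN1c1ccc(S(=O)(=O)Nc2cccc(Br)c2)cc1`) has not yet been measured. It differs from compound 2 by carrying 3-bromophenyl in place of 3,4-dimethylphenyl on a sulfonamide nitrogen. Among the compounds with values here, no measured pair tests this swap directly, so any forecast is rough. Compound 2 at 230 nM and compound 1 at 130 nM stay close although they carry different groups at that place, which points to a small change. The expected move is an estimated 1.3-fold higher number from compound 2 to compound 3 (0.12 log units; within the scatter) that would stay inside the scatter. For compound 3 the estimate is 300 nM with an expected range from 100 nM to 900 nM in this assay when it is tested.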

Compound 3, half-maximal inhibitory concentration: 77 nM
For compound 3 the middle estimate is 3.9-fold (0.59 log units) above the measured one; measured number outside the range, below it.
By their numbers in this assay, from the lowest: compounds 3, 1 and 2 (each within the scatter of the next, the first and the last beyond it).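

In this assay, the group on a sulfonamide nitrogen can move the number beyond the scatter: 3-bromophenyl in place of 3,4-dimethylphenyl gives a 3.0-fold lower number from compound 2 to compound 3 (0.48 log units; beyond the scatter), a modest step. Within the data shown here, the two earlier compounds sat within the scatter of each other and formed no direct pair for this swap, so they left it unclear whether this place mattered at all. Nothing measured here accounts for the size or direction of this step.

Compound 1 at 130 nM and compound 3 at 77 nM lie within the scatter of each other, so these two cannot be told apart. Going by these compounds, it stays open whether the bromine or the loss of the methyl groups drives the step, which a plain phenyl group or a 3-methylphenyl group at this place could help to separate.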